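A few compounds are considered here, and "the series" means these few. Any claim that something is new, unique, unknown or untested is made for them only; others in the source may bear on it.

Compound 1 (`CCOc1cc(C#N)cc(OCC)c1Oc1nc(Nc2ccc(C#N)cc2)nc2ccccc12`) was tested in an ADME assay on MT4 cells (Homo sapiens) for cytotoxicity, read by MTT assay, with a stated time of 4 days (on this read-out higher numbers stand for lower toxicity in this test and lower numbers for higher toxicity in this test), where compound 1 gives 108000 nM. Among the compounds described here, that is the only real number recorded in this assay; the other entry is a limit. Compound 2 (`Cc1cc(C)c(Oc2nc(Nc3ccc(C#N)cc3)nc3ccccc23)c(C)c1`) gives > 34000 nM in this assay, and this is a limit of the assay rather than a number. Among the measured compounds shown here, the evidence from the measured compounds therefore rests on (the limit of > 34000 nM in this assay, at which 1 of the 2 values shown sits), and no step between two measured compounds is available to guide the next case.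

Compound 3 (`CCOc1cc(C#N)cc(Cl)c1Oc1nc(Nc2ccc(C#N)cc2)nc2ccccc12`) has not yet been measured in this assay. It differs from compound 1 in one place: chloro in place of ethoxy on an aromatic carbon. For the measured compounds named here, with no measured step to go by, no change beyond the usual scatter is expected from this replacement; the estimated step, a 1.2-fold lower number from compound 1 to compound 3 (0.08 log units; within the scatter), is accordingly close to nil. On that basis compound 3 is estimated to give 90000 nM in this assay, with an expected range from 30000 nM to 200000 nM, and there is a fair chance that the assay returns only a limit.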

Compound 3, half-maximal cytotoxic concentration: 22000 nM
Compound 3: the middle estimate sits 4.1-fold (0.61 log units) above what was measured, and the stated range ends above it.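

With chloro in place of ethoxy on this aromatic carbon, ortho to a large group and meta to a cyano group, this assay shows a 4.9-fold lower number from compound 1 to compound 3 (0.69 log units; beyond the scatter). Among the compounds shown here, this is the first step between two measured compounds that differ in one place, and it shows that this position is not silent in the read-out: the exchange of the three heavy atoms of ethoxy for a single chlorine moves the number beyond the scatter, towards higher toxicity in this test. Nothing measured among the compounds shown speaks to the origin of this step.

One step cannot separate the loss of ethoxy from the arrival of chloro, and it also leaves open whether a fluoro group, a hydroxyl group, an amine or a longer chain such as propoxy on the same carbon would lower the number as far, less far or not at all. As far as these compounds go, it is equally open whether the same replacement at the ethoxy group that remains in compound 3 would give a step of similar size.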